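A few compounds are considered here, and "the series" means these few. Any claim that something is new, unique, unknown or untested is made for them only; others in the source may bear on it.

Measured so far:
- compound 1, `O=C(O)C1CCCN(CCC#Cc2cccc(N=Nc3cccc4ccccc34)c2)C1`: 18 h
- compound 2, `O=C(O)C1CCCN(CCCC#Cc2cccc(N=Nc3ccccc3)c2)C1`: 360 h

In a physicochemical assay for pharmacokinetics, read by spectrophotometry, in phosphate buffer, at pH 7.4, tested at 20 uM (on this read-out higher numbers stand for a longer-lived compound and lower numbers for a shorter-lived compound), compound 1 gives the lower of the two numbers; compound 2 sits well above it, and the gap between the two is beyond the scatter. Going by the values given here, the two measured compounds differ in more than one place, so no single step between them is on hand.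

Compound 3, `O=C(O)C1CCCN(CCCC#Cc2cccc(N=Nc3cccc4ccccc34)c2)C1`, carries the change ((3-carboxypiperidin-1-yl)methyl in place of 3-carboxypiperidin-1-yl on a saturated chain carbon, two bonds along the chain from a triple-bonded carbon). This brings the chain to the same length as in compound 2 while the aryl part of compound 1 stays. Which of the two differences between compound 1 and compound 2 accounts for the gap in this assay cannot be told from two compounds.

The step of a 3.3-fold higher number from compound 1 to compound 3 (0.52 log units; beyond the scatter) is expected to be a rise, smaller than the gap between the measured pair. Compound 3 is estimated at 60 h, with a range from 15 h to 250 h.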

Compound 3, half-life: 43.2 h
The estimate for compound 3 lay 1.4-fold (0.14 log units) above the measured number; low and high end bracket the measured number.
By their numbers in this assay, from the lowest: compound 1; then compound 3; then compound 2.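

In this assay, (3-carboxypiperidin-1-yl)methyl in place of 3-carboxypiperidin-1-yl on a saturated chain carbon, two bonds along the chain from a triple-bonded carbon, gives a 2.4-fold higher number from compound 1 to compound 3 (0.38 log units; beyond the scatter). With the chain length held, naphthalen-1-yl in place of phenyl on a double-bonded nitrogen gives an 8.3-fold lower number from compound 2 to compound 3 (0.92 log units; beyond the scatter), the larger of the two printed steps, so each of the two differences between compound 1 and compound 2 moves the half-life on its own, which the earlier pair could not show. Nothing at hand bears on why either change moves the half-life.

Open, from the compounds shown here alone, is whether the two steps add up, which would take the shorter chain paired with phenyl on the double-bonded nitrogen. Also open, going by these compounds, is how a still longer chain, or a methoxyphenyl group on that nitrogen, would read in this assay.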